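Replacing the formylamino group of compound 2 by an amidine

The source may hold more compounds than are shown below. What is called first, only, known or untested is meant among the compounds shown, and "the series" means these compounds.

Measured compounds:
compound 1, `Cc1nc2c(OCc3ccc(Cl)cc3)cccn2c1N`, 66%
compound 2, `Cc1nc2c(OCc3ccccc3)cccn2c1NC=O`, 49%
compound 3, `Cc1nc2c(OCc3ccccc3)cccn2c1NC(=O)OCc1ccccc1`, 8%

In a functional assay on the whole organism with Rattus norvegicus as the target, at a dose of 40 mg/kg by the intraperitoneal route (on this read-out higher numbers stand for more inhibition at the one dose given (going by the name of the read-out) and lower numbers for less inhibition), compound 2 stands second highest of the three numbers with 49%. Compound 1 gives 66%, and compound 3 gives 8%. Compound 4, `Cc1nc2c(OCc3ccccc3)cccn2c1/N=C/N(C)C`, has not been measured; it differs from compound 2 as follows: a group of 5 heavy atoms (3 carbon, 2 nitrogen; no ring) in place of a group of 3 heavy atoms (1 carbon, 1 nitrogen, 1 oxygen; no ring), on an aromatic carbon. Within the data shown here, the one measured step that bears on a change at this part of the molecule is a number 41 percentage points lower from compound 2 to compound 3 (beyond the scatter), where a far larger group entered. For compound 4 a group of 5 heavy atoms replaces one of 3 heavy atoms, so a smaller drop is expected, as the step of a number 19 percentage points lower from compound 2 to compound 4 (beyond the scatter). Compound 4 is therefore estimated at 30%, between 10% and 55%.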

Compound 4, a percentage reported as inhibition, in the whole organism at one dose (the size of the read-out at that dose, not a potency): 64%
Compound 4: middle estimate off by 34 percentage points, on the low side; measured number above the stated range.
By their numbers in this assay, from the lowest: compound 3; then compound 2; then compounds 4 and 1 (each within the scatter of the next).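

In this assay, the earlier step at this aromatic carbon ran downward as a larger group entered, a number 41 percentage points lower from compound 2 to compound 3 (beyond the scatter), whereas the amidine goes the other way, a number 15 percentage points higher from compound 2 to compound 4 (beyond the scatter). Size of the entering group alone therefore does not set the direction of the change at this position, and losing the hydrogen-bond donor of the formylamino group does not lower the number here. Nothing measured here accounts for the rise. Open, on these data alone, is how a plain amine on this carbon compares on the core of compound 4, and whether a longer chain on the amidine nitrogen keeps the number.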